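The compounds below may be only part of what the source reports. "The series", "measured", "known", "first", "only" and "open" are said of these compounds alone.

Measured in a physicochemical assay for lipophilicity, at pH 7.4; on this read-out higher numbers stand for higher lipophilicity and lower numbers for lower lipophilicity:

- compound 1 `Cc1[nH]c2ccccc2c(=O)c1Cc1ccccc1` gives 1.93
- compound 2 `COc1ccc2[nH]c(C)c(Br)c(=O)c2c1` gives 1.62
- compound 3 `CCCCC#Cc1c(C)[nH]c2ccc(OC)cc2c1=O` gives 5.25

Compound 3 stands highest of the three in this assay. Its number lies well beyond the usual scatter from both others, with the nearer being compound 1 at 1.93 and the further being compound 2 at 1.62.

The next compound to be measured is compound 4 `COc1ccc2[nH]c(C)c(Cc3ccccc3)c(=O)c2c1`, which carries benzyl in place of hex-1-yn-1-yl on an aromatic carbon.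

Within the data shown here, only one measured step bears directly on this change. Hex-1-yn-1-yl in place of bromo gave a number 3.63 log units higher from compound 2 to compound 3 (beyond the scatter), a large step beyond the scatter. That step shows how much the number can move at this place when hex-1-yn-1-yl enters, so its removal is expected to bring a large fall.

Compound 1 also carries benzyl and gives 1.93, though its core differs from that of compound 4, and the data do not show what this difference alone does. Its value therefore serves as a guide to the level expected, not as a direct reading.

The expected change is a number 3.15 log units lower from compound 3 to compound 4 (beyond the scatter), a large fall beyond the scatter. For compound 4 the estimate is 2.1, with an expected range from 1.6 to 2.8.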

Compound 4, distribution coefficient: 2.53
Compound 4: middle estimate off by 0.43 log units, on the low side; measured number inside the range.
By their numbers in this assay, from the lowest: compound 2; then compound 1; then compound 4; then compound 3.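

In this assay, a number 2.72 log units lower from compound 3 to compound 4 (beyond the scatter), so the high number of compound 3 does not carry over to benzyl, with its six-membered aromatic ring of carbon only and no triple bond outside aromatic rings. Benzyl still reads higher than bromo at this aromatic carbon, a number 0.91 log units higher from compound 2 to compound 4 (beyond the scatter), and this modest step is much smaller than the one to hex-1-yn-1-yl, which sets the three groups on the shared core in the order bromo, benzyl, hex-1-yn-1-yl. With benzyl held constant, methoxy in place of hydrogen on an aromatic carbon also counts, a number 0.60 log units higher from compound 1 to compound 4 (beyond the scatter), which gives a direct reading of the difference between the core of compound 1 and that of compound 4.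

Nothing here explains why the three groups fall in this order. From the compounds shown here alone, whether the high number of compound 3 goes with the triple bond or with the length of the chain stays open, a question that a saturated hexyl chain at this place could answer, and how an amine or a carboxylic acid would read there is also unknown.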